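The source may hold more compounds than are shown below. What is called first, only, known or untested is meant among the compounds shown, and "the series" means these compounds.

In a functional assay on A-431 cells (Homo sapiens) for cytotoxicity (a higher number here means that more compound is needed for the effect, a lower number that less compound is needed), three analogues on the shared core have been measured, differing only in the substituted phenyl group on the chain. Compound 1 `COC1=C(C)C(=O)/C(=C(O)/C=C/c2cccc(OC)c2)C(=O)C1(C)C` gives 4.5 ug/mL in this test. Compound 2 `COC1=C(C)C(=O)/C(=C(O)/C=C/c2ccc(C)cc2)C(=O)C1(C)C` gives 5.1 ug/mL and compound 3 `COC1=C(C)C(=O)/C(=C(O)/C=C/c2ccccc2C)C(=O)C1(C)C`, which carries a 2-methylphenyl group, gives 5.2 ug/mL here. Compound 3 thus stands level with the other two, with a 1.2-fold higher number from compound 1 to compound 3 (0.06 log units; within the scatter) and a 1.0-fold higher number from compound 2 to compound 3 (0.01 log units; within the scatter) as its steps. The remaining step, a 1.1-fold higher number from compound 1 to compound 2 (0.05 log units; within the scatter), is just as small.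

Compound 4 `COC1=C(C)C(=O)/C(=C(O)/C=C/c2c(C)cccc2C)C(=O)C1(C)C` turns the 2-methylphenyl into a 2,6-dimethylphenyl, with methyl in place of hydrogen on an aromatic carbon. Among the compounds with values here, no measured step adds a methyl in this way, so the evidence is indirect. Still, the phenyl changes seen so far, including a 1.0-fold higher number from compound 2 to compound 3 (0.01 log units; within the scatter) as the shift of a methyl group, have left the number flat, and no step beyond the scatter is expected.

The expected result is a 1.0-fold lower number from compound 3 to compound 4 (0.02 log units; within the scatter). Compound 4 is estimated at 5 ug/mL, with an expected range of 2.8 ug/mL to 9 ug/mL.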

Compound 4, concentration for half-maximal effect: 10.1 ug/mL
Estimate against measurement, compound 4: 2.0-fold (0.31 log units) below, outside the stated range (above it).
By their numbers in this assay, from the lowest: compounds 1, 2, 3 and 4 (each within the scatter of the next, the first and the last beyond it).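

Within the data shown here, the 2,6-dimethylphenyl group is the first change at this position to give a step beyond the scatter in this assay, although the step is modest and appears only against the 3-methoxyphenyl group (a 2.2-fold higher number from compound 1 to compound 4 (0.35 log units; beyond the scatter)). Adding the methyl group to the 2-methylphenyl group gives a step within the scatter (a 1.9-fold higher number from compound 3 to compound 4 (0.29 log units; within the scatter)), as does replacing the 4-methylphenyl group with the 2,6-dimethylphenyl group (a 2.0-fold higher number from compound 2 to compound 4 (0.30 log units; within the scatter)), yet both steps are larger than any among the three earlier compounds. Nothing available explains this result.

The compounds shown leave open whether an ethyl group or a chlorine atom in the same place would give a similar number. They also leave open how an amine on the phenyl ring would read in this test.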